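Trifluoromethyl in Place of Bromo: Estimating Compound 3

The source may hold more compounds than are shown below. What is called first, only, known or untested is meant among the compounds shown, and "the series" means these compounds.

Compound 1 `CC(=O)N1CCc2c(c(-c3ccc(I)cc3)nn2CC(O)CN2CCC(n3c(O)nc4ccccc43)CC2)C1` gives 120 nM in an assay on isolated protein for inhibition of cathepsin S (Homo sapiens); a lower number here means a stronger inhibitor, a higher number a weaker inhibitor.
Compound 2 `CC(=O)N1CCc2c(c(-c3ccc(Br)cc3)nn2CC(O)CN2CCC(n3c(O)nc4ccccc43)CC2)C1` gives 80 nM in this assay.

Among the measured compounds shown here, on the numbers so far, compound 2 stands beside compound 1 rather than apart from it: the step of a 1.5-fold lower number from compound 1 to compound 2 (0.18 log units; within the scatter) lies within the usual scatter, so the two compounds cannot be ranked against each other.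

Compound 3 `CC(=O)N1CCc2c(c(-c3ccc(C(F)(F)F)cc3)nn2CC(O)CN2CCC(n3c(O)nc4ccccc43)CC2)C1` differs from compound 2 in one place: trifluoromethyl in place of bromo on an aromatic carbon. For the measured compounds named here, the only measured step that bears on this position is the exchange of one halogen for another, from compound 1 to compound 2, and it was a 1.5-fold lower number from compound 1 to compound 2 (0.18 log units; within the scatter), a change too small to read. Going by the values given here, no measured step shows what a trifluoromethyl group does at this position, so the expectation can only rest on the fact that the one change made there so far moved the number within the scatter. The expected step from compound 2 to compound 3 in this assay is therefore a 1.3-fold higher number from compound 2 to compound 3 (0.10 log units; within the scatter), with no direction beyond the scatter. The estimate for compound 3 in this assay is 100 nM, with a range from 40 nM to 250 nM.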

Compound 3, half-maximal inhibitory concentration: 100 nM
Compound 3: the middle estimate sits on the measured number at the digits printed; measured number inside the range.
By their numbers in this assay, from the lowest: compounds 2, 3 and 1 (each within the scatter of the next).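

In this assay, putting trifluoromethyl in place of bromo gives a 1.3-fold higher number from compound 2 to compound 3 (0.10 log units; within the scatter) and putting it in place of iodo gives a 1.2-fold lower number from compound 1 to compound 3 (0.08 log units; within the scatter). Among the compounds shown here, until now the only exchange at this place, on the aromatic ring and para to a large group, was one halogen for another, whereas here a group of four heavy atoms takes the place of a single atom and the number still stays within the scatter, so compound 1, compound 2 and compound 3 cannot be ranked against one another. No other measurement is available that could explain why these three compounds cannot be told apart.

Going by these compounds, all three groups at this place are halogens or carry only fluorine on a single carbon, and none has a hydrogen-bond donor or acceptor, so it remains open whether an amine, a carboxylic acid or a longer chain would leave the number just as undisturbed. On these data alone, it also remains open how far this tolerance extends, since a single place on the shared core, read in one assay on isolated protein, says nothing about changes elsewhere in the molecule.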